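The source may report more compounds than this note shows. Statements on the series, on what has been measured and on what is new or still open speak of the compounds shown alone.

In a functional assay on MCF7 cells (Homo sapiens) for antiproliferative activity, read by CellTiter-Glo, with a stated time of 5 days (a higher number here means a weaker inhibitor, a lower number a stronger inhibitor), compound 1 `CC1=C(c2ccc(C#N)cc2)C(c2ccc(OC[C@H](C)N3CC[C@@H](C)C3)cc2)Oc2ccc(O)cc21` gives 10 nM and compound 2 `CC1=C(c2cccc(S(C)(=O)=O)c2)C(c2ccc(OC[C@H](C)N3CC[C@@H](C)C3)cc2)Oc2ccc(O)cc21` gives 4.3 nM on the same core. Compound 3 `CC1=C(c2cccc(O)c2)C(c2ccc(OC[C@H](C)N3CC[C@@H](C)C3)cc2)Oc2ccc(O)cc21` gives 0.2 nM as the lowest number of the three, clear of the scatter against both others. Compound 4 `CC1=C(c2ccc(F)cc2)C(c2ccc(OC[C@H](C)N3CC[C@@H](C)C3)cc2)Oc2ccc(O)cc21` departs from compound 3 in one place. The change is 4-fluorophenyl in place of 3-hydroxyphenyl on a double-bonded ring carbon and it sits on a double-bonded ring carbon of a six-membered non-aromatic ring with 1 oxygen, with 4-fluorophenyl in place of 3-hydroxyphenyl.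

Among the measured compounds shown here, two measured steps bear most directly on this change. With 3-hydroxyphenyl in place of 4-cyanophenyl the series shows a 50-fold lower number from compound 1 to compound 3 (1.70 log units; beyond the scatter) and with hydroxy in place of methylsulfonyl it shows a 22-fold lower number from compound 2 to compound 3 (1.33 log units; beyond the scatter) as a second large step. Between the two compounds lacking that hydroxy, a 2.3-fold lower number from compound 1 to compound 2 (0.37 log units; beyond the scatter) is only modest. For the measured compounds named here, no compound with 4-fluorophenyl has been measured, so the read-across rests on these three compounds alone. A large step toward a higher number is therefore expected in this assay with a size somewhat under those two. The expected step is a 15-fold higher number from compound 3 to compound 4 (1.18 log units; beyond the scatter) as the working figure. Compound 4 is estimated at 3 nM with an expected range from 0.8 nM to 10 nM in this series.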

Compound 4, half-maximal inhibitory concentration: 0.4 nM
Compound 4: the middle estimate sits 7.5-fold (0.88 log units) above what was measured, outside the stated range (below it).
By their numbers in this assay, from the lowest: compounds 3 and 4 (each within the scatter of the next); then compound 2; then compound 1.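

In this assay, among the compounds shown here, the 3-hydroxyphenyl is not the only group on this double-bonded ring carbon to give a very low number: 4-fluorophenyl, which carries no hydroxy, shows a 2.0-fold higher number from compound 3 to compound 4 (0.30 log units; within the scatter), so the large steps to compound 3 cannot be read as the effect of the hydroxy alone. Among the compounds without that hydroxy, the group on the phenyl ring now separates the numbers widely, with fluoro in place of cyano giving a 25-fold lower number from compound 1 to compound 4 (1.40 log units; beyond the scatter) and 4-fluorophenyl in place of 3-(methylsulfonyl)phenyl giving an 11-fold lower number from compound 2 to compound 4 (1.03 log units; beyond the scatter). Nothing measured on these compounds explains why compound 3 and compound 4 stand together, well apart from compound 1 and compound 2.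

In this set, the substituent and its place on the phenyl ring change together between compound 3 and compound 4, and between compound 2 and compound 4, so their contributions remain unseparated. Still open, from the compounds shown here alone, is where an unsubstituted phenyl, a 3-fluorophenyl, a 4-hydroxyphenyl or a phenyl bearing an amine or a carboxylic acid would fall in this assay.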